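Ketone-bearing ring: hexyloxy against methyl in the series

This account rests on a few compounds, and the source may have more. Where it says the series, first, only, none or still open, it means among the compounds named here.

Of the compounds shown here, three of the shared core have been measured in a functional assay on B16-F10 cells (Mus musculus) for antiproliferative activity, read by MTT assay, with a stated time of 48 h; a higher number here means a weaker inhibitor, a lower number a stronger inhibitor. Compound 1 `COc1ccc(/C=C/c2cc(OC)cc(OC)c2/C=C/C(=O)c2ccccc2)cc1` gives 3.7 ug/mL. Compound 2 `CCCCCCOc1ccc(C(=O)/C=C/c2c(/C=C/c3ccc(OC)cc3)cc(OC)cc2OC)cc1`, which carries a hexyloxy group, gives 10.4 ug/mL, the highest number of the three. Compound 3 `COc1ccc(/C=C/c2cc(OC)cc(OC)c2/C=C/C(=O)c2ccc(OC)cc2)cc1` gives 5.8 ug/mL.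

Compound 4 `COc1ccc(/C=C/c2cc(OC)cc(OC)c2/C=C/C(=O)c2ccc(C)cc2)cc1` is not yet measured. It differs from compound 2 by methyl in place of hexyloxy on an aromatic carbon.

The bearing steps are these: a 2.8-fold higher number from compound 1 to compound 2 (0.45 log units; beyond the scatter); a 1.6-fold higher number from compound 1 to compound 3 (0.20 log units; within the scatter); a 1.8-fold lower number from compound 2 to compound 3 (0.25 log units; within the scatter). So the hexyloxy group is the only change among the three that moved the number beyond the scatter, and removing it as far as methoxy in compound 3 brings the number back close to compound 1. A methyl group at the same place is a small group, like the methoxy of compound 3 and the hydrogen of compound 1, so a lower number than compound 2 is expected, of roughly the size seen in the step from compound 1 to compound 2, reversed. This would mean an expected step of a 1.9-fold lower number from compound 2 to compound 4 (0.28 log units; within the scatter). Compound 4 is therefore estimated at 5.5 ug/mL, with a range of 2.5 ug/mL to 12 ug/mL.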

Compound 4, half-maximal inhibitory concentration: 5.3 ug/mL
Beside the measured number, compound 4's estimate is 1.0-fold (0.02 log units) above it; the measured number falls inside the stated range.
By their numbers in this assay, from the lowest: compounds 1, 4, 3 and 2 (each within the scatter of the next, the first and the last beyond it).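

At this position, methyl brings in a group with no oxygen and no hydrogen-bond acceptor, yet in this assay it cannot be told apart from methoxy or hydrogen: a 1.1-fold lower number from compound 3 to compound 4 (0.04 log units; within the scatter) and a 1.4-fold higher number from compound 1 to compound 4 (0.16 log units; within the scatter). Hydrogen, methoxy and methyl therefore all lie within the scatter of one another, so an oxygen at this place is not required for compound 4 to stand with compound 1 and compound 3. Hexyloxy also stands apart less clearly than a single comparison suggested, since a 2.0-fold lower number from compound 2 to compound 4 (0.29 log units; within the scatter) is within the scatter and only a 2.8-fold higher number from compound 1 to compound 2 (0.45 log units; beyond the scatter) lies beyond it.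

Nothing available here offers a reason for these numbers. Still open, from the compounds shown here alone, is whether a butoxy chain, a chain longer than hexyloxy or an amine at this place would move the number beyond the scatter from compound 1.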